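From 2-carbamoylthiophen-3-yl to 2-carbamoylphenyl on an amide-type nitrogen

A few compounds are considered here, and "the series" means these few. Any claim that something is new, unique, unknown or untested is made for them only; others in the source may bear on it.

In an ADME assay on MDCK cells (Canis lupus familiaris) for cytotoxicity, read by MTT assay, with a stated time of 48 h (a lower number here means that less compound is tolerated, a higher number that more compound is tolerated), compound 1 (`Cc1cc(-c2ccccc2)n2nc(C(=O)Nc3c(C(N)=O)sc4c3CCCCC4)nc2n1`) gives 90000 nM as its reading. Compound 2 (`Cc1cc(-c2ccccc2)n2nc(C(=O)Nc3ccsc3C(N)=O)nc2n1`) gives 250000 nM and so holds the higher of the two numbers, with a gap to compound 1 that lies beyond the usual scatter.

Compound 3 (`Cc1cc(-c2ccccc2)n2nc(C(=O)Nc3ccccc3C(N)=O)nc2n1`) is the next to be read. It carries 2-carbamoylphenyl in place of 2-carbamoylthiophen-3-yl on an amide-type nitrogen. Among the measured compounds shown here, no measured pair in this small set differs in one place only, so the size of this step has no direct precedent. For the measured compounds named here, the only guide is the span of the two known numbers, from compound 2 at 250000 nM down to compound 1 at 90000 nM on the same scale. A modest move toward a lower number is expected, one that does not clearly leave the scatter. The estimated change is a 1.6-fold lower number from compound 2 to compound 3 (0.19 log units; within the scatter) and would remain within the scatter. Compound 3 is expected to read near 160000 nM and is estimated to fall between 70000 nM and 320000 nM.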

Compound 3, half-maximal cytotoxic concentration: > 250000 nM
Compound 3: a limit, no number; the forecaster's own chance of this, stated with the estimate: 15%; at least 1.5-fold (0.19 log units) between middle value and limit.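

In this assay compound 3 gives > 250000 nM, which is a limit of the assay and not a number. On the amide-type nitrogen, 2-carbamoylphenyl in place of 2-carbamoylthiophen-3-yl gives a number no lower from compound 2 to compound 3 (the limit leaves the size open), so this position takes a six-membered aromatic ring of carbon only in place of a five-membered aromatic ring with 1 hetero atom, and the ring sulfur is not needed for a reading this high in this pair. The size of this step cannot be read, and the comparison rests on a single bound: the limit of > 250000 nM in this assay, at which 1 of the 3 values shown sits.

On these data alone, how far the true reading of compound 3 lies from that of compound 2 stays open, as does whether the two differ beyond the usual scatter at all. Also open, as far as these compounds go, is how this series would read in this assay with a carboxylic acid in place of the carbamoyl group of 2-carbamoylphenyl, or with an amine as a further group on that six-membered ring.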